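This account rests on a few compounds, and the source may have more. Where it says the series, first, only, none or still open, it means among the compounds named here.

Measured compounds in an assay on isolated protein for inhibition of Amine oxidase [flavin-containing] B (Homo sapiens), read by fluorescence; on this read-out lower numbers stand for stronger inhibition and higher numbers for weaker inhibition:
compound 1 `O=C(/C=C/c1ccsc1)c1cc(O)c(O)c([N+](=O)[O-])c1`, 42100 nM;
compound 2 `O=C(/C=C/c1ccoc1)c1cc(O)c(O)c([N+](=O)[O-])c1`, 71400 nM;
compound 3 `O=C(/C=C/c1ccco1)c1cc(O)c(O)c([N+](=O)[O-])c1`, 68200 nM.

Compound 3 gives the second highest of the three numbers in this assay. Its nearest neighbour is compound 2, with a 1.0-fold lower number from compound 2 to compound 3 (0.02 log units; within the scatter), and its furthest is compound 1, with a 1.6-fold higher number from compound 1 to compound 3 (0.21 log units; within the scatter); both steps sit within the scatter, so the three compounds cannot be told apart on these data.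

The next compound, compound 4 `Cn1cc(/C=C/C(=O)c2cc(O)c(O)c([N+](=O)[O-])c2)cn1`, differs from compound 3 in one place: 1-methyl-1H-pyrazol-4-yl in place of furan-2-yl on a double-bonded chain carbon bound to a double-bonded chain carbon. Among the measured compounds shown here, the steps that bear on this change are the exchanges of the five-membered aromatic ring on the same chain carbon, a 1.7-fold higher number from compound 1 to compound 2 (0.23 log units; within the scatter), a 1.6-fold higher number from compound 1 to compound 3 (0.21 log units; within the scatter) and a 1.0-fold lower number from compound 2 to compound 3 (0.02 log units; within the scatter). Each lies within the scatter. A step beyond the scatter in this assay is therefore not expected from compound 3 to compound 4 in either direction, and the expected step is a 1.1-fold lower number from compound 3 to compound 4 (0.06 log units; within the scatter). Compound 4 is estimated at 60000 nM in this assay, with a range from 20000 nM to 180000 nM.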

Compound 4, half-maximal inhibitory concentration: 66200 nM
Compound 4: the middle estimate sits 1.1-fold (0.04 log units) below what was measured, and the stated range covers the measured number.
By their numbers in this assay, from the lowest: compounds 1, 4, 3 and 2 (each within the scatter of the next).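

In this assay the step to 1-methyl-1H-pyrazol-4-yl on this double-bonded chain carbon stays within the scatter from each earlier ring (a 1.0-fold lower number from compound 3 to compound 4 (0.01 log units; within the scatter); a 1.1-fold lower number from compound 2 to compound 4 (0.03 log units; within the scatter); a 1.6-fold higher number from compound 1 to compound 4 (0.20 log units; within the scatter)). The place thus tolerates, without a step that can be read, a ring with 2 hetero atoms, both nitrogen, and 6 heavy atoms as well as the rings with 1 hetero atom, so the four compounds cannot be told apart. No measurement shown offers any explanation for this result.

All four compounds carry a five-membered aromatic ring at this place, so the data leave open whether a phenyl ring, a pyridine ring, an amine or a longer chain there would give a step beyond the scatter. They also leave open what replacing the nitro group of the shared core with a nitrile would do.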